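Replacing a Cyanophenyl Arm with Methylpyridinyl

The source may hold more compounds than are shown below. What is called first, only, known or untested is meant among the compounds shown, and "the series" means these compounds.

Three measured compounds share one core. Compound 1 `COC(=O)c1cccc(-c2cnc(C(=O)CCCCCCc3ccccc3)o2)c1` gives 12 nM in an assay (Rattus norvegicus) for inhibition of Fatty-acid amide hydrolase 1 (Homo sapiens); on this read-out lower numbers stand for stronger inhibition and higher numbers for weaker inhibition. Compound 2 `O=C(CCCCCCc1ccccc1)c1ncc(-c2cccc(C(=O)C(F)(F)F)c2)o1` gives 16 nM, and compound 3 `N#Cc1cccc(-c2cnc(C(=O)CCCCCCc3ccccc3)o2)c1` gives 15 nM. Compound 3 sits between its two neighbours on these numbers, with a 1.3-fold higher number from compound 1 to compound 3 (0.10 log units; within the scatter) and a 1.1-fold lower number from compound 2 to compound 3 (0.03 log units; within the scatter), so none of the three is separated from another beyond the scatter. The step from compound 1 to compound 2, a 1.3-fold higher number from compound 1 to compound 2 (0.12 log units; within the scatter), is likewise within the scatter.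

Compound 4 `Cc1ccc(-c2cnc(C(=O)CCCCCCc3ccccc3)o2)nc1` is not yet measured. Its change from compound 3 is 5-methylpyridin-2-yl in place of 3-cyanophenyl on an aromatic carbon. Going by the values given here, none of the measured steps exchanges the phenyl ring itself for a ring with a hetero atom; they only vary the group on that ring, and each such variation left the number essentially unchanged. The data therefore give no direct guide, and the expectation rests on the flatness seen so far. Compound 4 is expected to give about 20 nM, within 6 nM to 65 nM, a step of a 1.3-fold higher number from compound 3 to compound 4 (0.12 log units; within the scatter) that is expected to stay within the scatter.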

Compound 4, inhibition constant: 2.8 nM
The estimate for compound 4 lay 7.1-fold (0.85 log units) above the measured number; the measured number lies below the stated range.
By their numbers in this assay, from the lowest: compound 4; then compounds 1, 3 and 2 (each within the scatter of the next).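

Exchanging the ring itself moves the number where varying a group on the phenyl ring did not: in this assay, 5-methylpyridin-2-yl in place of 3-cyanophenyl gives a 5.4-fold lower number from compound 3 to compound 4 (0.73 log units; beyond the scatter), whereas compound 1, compound 2 and compound 3 all lie within the scatter of one another. This position, on an aromatic carbon next to the ring oxygen, is therefore not indifferent to what it carries, at least for this ring exchange. The change brings in a ring with 1 hetero atom and a methyl group and removes the nitrile all at once, and nothing available here explains the lower number.

Open is whether the ring nitrogen or the methyl group carries the step, as the compounds shown never separate the two. Also open, as far as these compounds go, is how an amine or a carboxylic acid in place of that methyl group would read in this assay.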